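Swapping Benzyloxy for Methylsulfonyl on a Biaryl Amide

The compounds below may be only part of what the source reports. "The series", "measured", "known", "first", "only" and "open" are said of these compounds alone.

Of the compounds shown here, three from this series have been tested in an ADME assay on HepG2 cells (Homo sapiens) for cytotoxicity, read by CellTiter-Glo and resazurin assay, with a stated time of 72 h (a lower number here means that less compound is needed, a higher number that more compound is needed for the effect), and all three gave only a limit. Compound 1, `CC(C)N(Cc1cccc(OCCCCCC(=O)O)c1)C(=O)c1ccc(-c2cccc(OCc3ccccc3)c2)cc1`, gave > 26000 nM, which is a limit of the assay and not a number. Compound 2, `CCOC(=O)CCCCCOc1cccc(CN(C(=O)c2ccccc2)C(C)C)c1`, gave > 26000 nM, also a limit. Compound 3, `CCOC(=O)CCCCCOc1cccc(CN(C(=O)c2ccc(-c3cccc(OCc4ccccc4)c3)cc2)C(C)C)c1`, gave > 26000 nM, once more a limit. Compound 3 thus stands where every measured compound in the study stands, namely at the limit of > 26000 nM in this assay, at which 3 of the 3 values shown sit. Among the compounds with values here, only one pair of measured compounds differs in a single place: the step that the two limits leave unreadable from compound 1 to compound 3, ethyl in place of hydrogen on an oxygen next to a carbonyl group. Both of its ends are limits, and the size of that step stays unreadable.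

Compound 4, `CCOC(=O)CCCCCOc1cccc(CN(C(=O)c2ccc(-c3cccc(S(C)(=O)=O)c3)cc2)C(C)C)c1`, has not yet been measured. It differs from compound 3 by methylsulfonyl in place of benzyloxy on an aromatic carbon. Within the data shown here, none of the measured steps touches this part of the molecule, and the one step that exists cannot be sized, so no measured step points to a change in either direction beyond the scatter. In this assay compound 4 is expected to give about 30000 nM, with a range from 12000 nM to 100000 nM, and most probably again only a limit. That estimate means an expected step that the limit leaves unreadable from compound 3 to compound 4, which is expected to lie within the scatter.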

Compound 4, half-maximal effective concentration: > 26000 nM
Compound 4: a limit, no number; the forecaster's own chance of this, stated with the estimate: 85%; the middle value lies beyond the limit too.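

In this assay compound 4 gives only a limit, as do compound 2 and compound 3, so the steps from these two compounds to compound 4 cannot be read. The compounds shown leave open how far each lies beyond that limit, and whether any change to the shared core would give a measurable number: the limit of > 26000 nM in this assay, at which 4 of the 4 values shown sit.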